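The source may hold more compounds than are shown below. What is called first, only, known or untested is meant among the compounds shown, and "the series" means these compounds.

The measured compounds:

Compound 1 `O=C(COc1ccc(C(=O)/C=C/c2cccc(Cl)c2)cc1)N[C@H]1CCOC1=O` gives 29100 nM.
Compound 2 `O=C(CNc1ccccc1)N[C@H]1CCOC1=O` reaches only a limit of the assay, > 64000 nM.
Compound 3 `O=C(COc1ccc(C(=O)/C=C/c2ccccc2)cc1)N[C@H]1CCOC1=O` likewise reaches only a limit of the assay, > 64000 nM.

All three were tested in a functional assay on MGC-803 cells (Homo sapiens) for antiproliferative activity, read by MTT assay, with a stated time of 72 h; on this read-out lower numbers stand for stronger inhibition and higher numbers for weaker inhibition. Compound 1 and compound 3 share one core and differ only in chloro in place of hydrogen on an aromatic carbon; this change gave an at least 2.1-fold lower number from compound 3 to compound 1 (0.34 log units; beyond the scatter). That step can be given only as a lower bound because of the limit of > 64000 nM in this assay, at which 2 of the 3 values shown sit.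

Compound 4 `O=C(CNc1ccccc1Cl)N[C@H]1CCOC1=O` has not been measured yet. It differs from compound 2 by chloro in place of hydrogen on an aromatic carbon. The difference between the core of compound 2 and the core of compound 3 is not broken down here. The change from compound 2 to compound 4 is the same kind of change as that from compound 3 to compound 1, not the same: in compound 1 the chloro sits meta to a large group, in compound 4 it sits ortho to a large group.

Since compound 2 shows only a limit, the expected step is harder to place; it is estimated as an at least 1.0-fold lower number from compound 2 to compound 4 (0.02 log units; that floor lies within the scatter), resting on the step of an at least 2.1-fold lower number from compound 3 to compound 1 (0.34 log units; beyond the scatter) and on compound 2 sitting at > 64000 nM. Compound 4 is therefore expected to give around 60000 nM in this assay, most likely between 25000 nM and 150000 nM, with a fair chance that only a limit is reported again.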

Compound 4, half-maximal inhibitory concentration: > 64000 nM
Compound 4 gave a limit, no number; the forecaster's own chance of this, stated with the estimate: 65%; middle value at least 1.0-fold (0.02 log units) from the limit.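

In this assay compound 4 reaches only a limit of the assay (> 64000 nM). Compound 2 sits at a limit as well, and no step can be read between compound 2 and compound 4: the limit of > 64000 nM in this assay, at which 3 of the 4 values shown sit. The compounds shown leave open whether chloro in place of hydrogen changes the antiproliferative activity at all on the core that compound 2 and compound 4 share.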